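Cytotoxicity on Vero cells: methoxy removal in the quinolone series

A few compounds are considered here, and "the series" means these few. Any claim that something is new, unique, unknown or untested is made for them only; others in the source may bear on it.

Compound 1 `COc1ccc(N2CCN(CNC(=O)c3cnccn3)CC2)cc1` carries the shared pyrazine-carboxamide tail on a simple aryl piperazine; in a functional assay on Vero cells (Chlorocebus sabaeus) for cytotoxicity, read by MTT assay (on this read-out higher numbers stand for lower toxicity in this test and lower numbers for higher toxicity in this test), compound 1 gives "not determined" (no result reported). Compound 2 `CCn1cc(C(=O)O)c(=O)c2cc(F)c(N3CCN(CNC(=O)c4cnccn4)CC3)cc21` attaches the same tail to a quinolone acid. In this assay compound 2 gives > 62.5 ug/mL, which is a limit of the assay and not a number. Compound 3 `COc1c(N2CCN(CNC(=O)c3cnccn3)CC2)c(F)cc2c(=O)c(C(=O)O)cn(C3CC3)c12` is the methoxy-bearing, cyclopropyl quinolone analogue. In this assay compound 3 gives > 62.5 ug/mL, again a limit and not a number. Compound 3 therefore stands at the limit of > 62.5 ug/mL in this assay, at which 2 of the 3 values shown sit, with no single value to rank it against the others.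

Compound 4 `O=C(NCN1CCN(c2cc3c(cc2F)c(=O)c(C(=O)O)cn3C2CC2)CC1)c1cnccn1` differs from compound 3 by hydrogen in place of methoxy on an aromatic carbon. Among the measured compounds shown here, no measured pair shows such a change, so no size of step in this assay can be read off; with both quinolone values sitting at the limit, no shift beyond the scatter is expected, and the step that the limit leaves unreadable from compound 3 to compound 4 is the estimate. Compound 4 is expected to give 70 ug/mL, within 35 ug/mL to 150 ug/mL.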

Compound 4, half-maximal cytotoxic concentration: > 62.5 ug/mL
Compound 4: a limit, no number (the forecaster's own chance of this, stated with the estimate: 80%); the middle value is on the limit's open side.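

In this assay compound 4 gives > 62.5 ug/mL, a limit and not a number. No step from compound 2 or compound 3 to compound 4 can be read, as all three sit at one limit: the limit of > 62.5 ug/mL in this assay, at which 3 of the 4 values shown sit.

Still open, on these data alone, is whether hydrogen in place of methoxy, or cyclopropyl in place of ethyl, shifts the read-out at all.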